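Trimming a Dimethylamino Group to Amino

The source may report more compounds than this note shows. Statements on the series, on what has been measured and on what is new or still open speak of the compounds shown alone.

Of the compounds shown here, two have been measured in an assay on isolated protein for inhibition of cytochrome P450 2A6 (Homo sapiens), read by fluorescence, with a stated time of 10 min; on this read-out higher numbers stand for weaker inhibition and lower numbers for stronger inhibition. Compound 1, with the structure `NCc1csc2ccc(Br)cc12`, gives 700 nM in this assay. Compound 2, with the structure `CN(C)Cc1cc2cnccc2s1`, gives 1400 nM in this assay. These two numbers sit within the usual scatter of each other, so nothing separates them with confidence, and the two compounds also differ in more than one place, so no single change can be read from that pair.

The step of interest leads from compound 2 to compound 3, whose structure is `NCc1cc2cnccc2s1` and which has not yet been measured. The change is amino in place of dimethylamino on a saturated chain carbon bound to an aromatic carbon. Compound 1 already carries an amino group on a saturated chain carbon, though on a different core, so the data give no direct reading of this change on the core that compound 2 and compound 3 share.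

Among the compounds with values here, with no measured step of this kind to lean on, the expected step from compound 2 to compound 3 in this assay is a 1.6-fold lower number from compound 2 to compound 3 (0.19 log units; within the scatter), which is small and stays close to the scatter. Compound 3 is therefore expected to give 900 nM in this assay, with a range from 300 nM to 2700 nM.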

Compound 3, half-maximal inhibitory concentration: 1000 nM
Compound 3: middle estimate off by 1.1-fold (0.05 log units), on the low side; measured number inside the range.
By their numbers in this assay, from the lowest: compounds 1, 3 and 2 (each within the scatter of the next).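

On the shared core of compound 2 and compound 3, the exchange of dimethylamino for amino on a saturated chain carbon bound to an aromatic carbon can now be read directly: in this assay the step is a 1.4-fold lower number from compound 2 to compound 3 (0.15 log units; within the scatter) and lies within the usual scatter of repeated measurements. At this position, then, going from a group of 3 heavy atoms with 0 hydrogen-bond donors to a group of 1 heavy atom with 1 hydrogen-bond donor gives no difference that can be told from noise in this one pair. No independent measurement bears on this result, so it stands as a bare observation without an explanation.

Within the data shown here, compound 1 differs from the other two compounds in more than one place, so no step to it can be read, and whether the same exchange would behave alike on the core of compound 1 stays open. Also open, as far as these compounds go, is how this position responds to groups outside this pair, such as methylamino, a pyrrolidine ring or an acetamide, any of which could show whether it tolerates larger changes as well.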